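A few compounds are considered here, and "the series" means these few. Any claim that something is new, unique, unknown or untested is made for them only; others in the source may bear on it.

Among the measured compounds shown here, compound 2 `c1ccc2c(c1)CCC2NC1CCN(CCCc2c[nH]c3ccc(-n4cnnc4)cc23)CC1` gives 8.9 nM in an assay on CHO cells for displacement of a labelled ligand from 5-hydroxytryptamine receptor 1D (Homo sapiens) (a lower number here means a stronger inhibitor, a higher number a weaker inhibitor), and this stands as the higher of the two numbers measured so far. Its nearest neighbour is compound 1 `O=S(=O)(NCC1CCN(CCCc2c[nH]c3ccc(-n4cnnc4)cc23)CC1)c1ccccc1`, which in this assay gives 6.2 nM; the step of a 1.4-fold higher number from compound 1 to compound 2 (0.16 log units; within the scatter) lies within the scatter. Compound 3 `c1cc(CNC2CCN(CCCc3c[nH]c4ccc(-n5cnnc5)cc34)CC2)co1` has not yet been measured; it differs from compound 2 by (furan-3-yl)methyl in place of 2,3-dihydro-1H-inden-1-yl on an amine nitrogen. For the measured compounds named here, only one measured step bears on this change, and only loosely: from compound 1 to compound 2 the group on the saturated ring carbon was exchanged, and the number barely moved. Nothing measured speaks directly to the exchange on the amine nitrogen. For compound 3 the expected step is therefore a 1.3-fold higher number from compound 2 to compound 3 (0.13 log units; within the scatter), none beyond the scatter. On that basis compound 3 is estimated at 12 nM in this assay, within a range from 4 nM to 40 nM.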

Compound 3, half-maximal inhibitory concentration: 4.5 nM
The estimate for compound 3 lay 2.7-fold (0.43 log units) above the measured number; the range from low to high includes it.
By their numbers in this assay, from the lowest: compounds 3, 1 and 2 (each within the scatter of the next).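

In this assay the exchange on the amine nitrogen gives a 2.0-fold lower number from compound 2 to compound 3 (0.30 log units; within the scatter), so (furan-3-yl)methyl, with 6 heavy atoms in place of 9 and an oxygen in its five-membered aromatic ring, stands level with 2,3-dihydro-1H-inden-1-yl at this position. The comparison with the sulfonamide gives a 1.4-fold lower number from compound 1 to compound 3 (0.14 log units; within the scatter), so all three groups on the saturated ring carbon remain within the scatter of one another, and the change from a fused carbon ring to a furan opens no measurable gap. Nothing available offers an explanation for these numbers. On these data alone, all three compounds carry an aromatic ring in this group, so whether a plain methyl or a carboxylic acid on the amine nitrogen would stay in the same range remains open. As far as these compounds go, whether the three compounds also stay level at any other receptor is equally open.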